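A few compounds are considered here, and "the series" means these few. Any claim that something is new, unique, unknown or untested is made for them only; others in the source may bear on it.

Compound 1, whose structure is `Fc1ccc(-n2cc(COc3ccccc3-c3nc4ccccc4s3)nn2)cc1`, was tested in a functional assay on MCF7 cells (Homo sapiens) for cytotoxicity, read by MTT assay, with a stated time of 24 h (on this read-out higher numbers stand for weaker inhibition and lower numbers for stronger inhibition), where compound 1 gives 26200 nM. Two further compounds of the same core were measured alongside it. Compound 3, with structure `COc1cc(-c2cc(COc3ccccc3-c3nc4ccccc4s3)on2)cc(OC)c1OC`, gives 25600 nM in this assay. Compound 2, with structure `FC(F)(F)C(F)(F)C(F)(F)C(F)(F)C(F)(F)C(F)(F)C(F)(F)C(F)(F)CCn1cc(COc2ccccc2-c2nc3ccccc3s2)nn1`, gives 19200 nM in this assay. The number for compound 1 differs from those of compound 3 and compound 2 by less than the usual scatter of this kind of measurement, so the three cannot be told apart on these data; none stands out as stronger or weaker than the others.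

Compound 4, with structure `c1ccc(-n2cc(COc3ccccc3-c3nc4ccccc4s3)nn2)cc1`, has not yet been measured. It differs from compound 1 in one place only: hydrogen in place of fluoro on an aromatic carbon. Among the compounds with values here, nothing among the measured compounds shows what removing a single fluoro from an aromatic carbon does here, since no pair of measured compounds differs in that way. With so small a change, and with the three measured compounds all sitting close together, the step from compound 1 to compound 4 is expected to be a 1.0-fold lower number from compound 1 to compound 4 (0.00 log units; within the scatter), that is, no change beyond the scatter in either direction. On that basis compound 4 is expected to give about 26000 nM in this assay, with a likely range from 11000 nM to 65000 nM.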

Compound 4, half-maximal inhibitory concentration: 26200 nM
Estimate against measurement, compound 4: 1.0-fold (0.00 log units) below; the range from low to high includes it.
By their numbers in this assay, from the lowest: compounds 2, 3, 1 and 4 (each within the scatter of the next).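

In this assay, replacing the fluoro with hydrogen gives no change at the digits printed from compound 1 to compound 4 (within the scatter). This pair is the first among the compounds shown that isolates a single change, so the effect of this position can now be read directly instead of being inferred from compounds that differ in more than one place. On the aromatic carbon para to a large group, the step from 4-fluorophenyl to phenyl leaves the cell read-out unchanged within the scatter, so the fluoro is not required to keep this level of activity, and no data here bear on why the number holds steady.

Fluoro and hydrogen are the only two groups that can be compared on this carbon, so what an amine, a carboxylic acid or a methoxy group there would do remains open. Also open, going by these compounds, is whether the same swap would leave the number unchanged on a different core, as this single pair speaks only for the core of compound 1.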